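Methyl Additions on Two Aryloxy Acid Cores

The source may hold more compounds than are shown below. What is called first, only, known or untested is meant among the compounds shown, and "the series" means these compounds.

Three compounds have been measured in a functional assay on the whole organism for inhibition, with Rattus norvegicus as the target; on this read-out lower numbers stand for an effect already at smaller amounts and higher numbers for an effect only at larger amounts of compound:
Compound 1 `CC(C)c1ccc(OC(Cc2ccc3ccccc3c2)C(=O)O)cc1` gives 50 mg/kg.
Compound 2 `CC(C)c1ccc(OC(C)(Cc2ccc3ccccc3c2)C(=O)O)cc1` gives > 10 mg/kg, which is a limit of the assay and not a number.
Compound 3 `CCc1ccc(CC(C)(Oc2ccc(Cc3ccccc3)cc2)C(=O)O)cc1` gives 1 mg/kg.

Compound 1 and compound 2 differ by methyl in place of hydrogen on a saturated chain carbon bound to a carbonyl carbon, an oxygen on an aromatic ring and a saturated chain carbon. The size of the step that the limit leaves unreadable from compound 1 to compound 2 cannot be read, since (the limit of > 10 mg/kg in this assay, at which 1 of the 3 values shown sits). Compound 3 shows the lowest of the two numbers; the difference between its core and the core of compound 1 is not broken down here. Compound 4 `CCCc1ccc(CC(C)(Oc2ccc(Cc3ccccc3)cc2)C(=O)O)cc1` carries the same kind of change as compound 2 carries relative to compound 1, but in another place: methyl in place of hydrogen on a saturated chain carbon, two bonds along the chain from an aromatic carbon. Here the methyl enters two bonds along the chain from an aromatic carbon, rather than on a saturated chain carbon bound to a carbonyl carbon, an oxygen on an aromatic ring and a saturated chain carbon. With the earlier step unreadable, the expectation rests on compound 3 at 1 mg/kg alone. Compound 4 is therefore expected to give 1 mg/kg, estimated between 0.4 mg/kg and 3 mg/kg. The expected step of no change at the digits printed from compound 3 to compound 4 (within the scatter) is estimated to stay within the usual scatter.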

Compound 4, dose for half-maximal effect: 1 mg/kg
For compound 4 middle estimate and measured number coincide at the digits printed; low and high end bracket the measured number.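

In this assay, methyl in place of hydrogen on a saturated chain carbon, two bonds along the chain from an aromatic carbon, gives no change at the digits printed from compound 3 to compound 4 (within the scatter) on this core. This one readable step shows that ethyl to propyl leaves the read-out within the scatter here, but it sets no rule for carrying a methyl from one core to another. The only step on the core of compound 1 cannot be read, because compound 2 stands at a limit of the assay and not at a number: the limit of > 10 mg/kg in this assay, at which 1 of the 4 values shown sits.

The compounds shown leave open whether a longer chain, such as butyl in place of the propyl of compound 4, would also stay within the scatter. They also leave open what an amine or a hydroxyl group at the end of that chain would do to the read-out.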